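Swapping the aryl group on a triazole acetamide series

The source may report more compounds than this note shows. Statements on the series, on what has been measured and on what is new or still open speak of the compounds shown alone.

Compound 1 `Cc1cc(NC(=O)Cn2cc(-c3cccc(Cl)c3)nn2)no1`: > 30000 nM
Compound 2 `O=C(Cn1cc(-c2cccc(Cl)c2)nn1)Nc1nccs1`: > 30000 nM

The two measured compounds share a core and were tested in a functional assay on BMDM cells (Mus musculus, strain C57BL/6) for inhibition, with a stated time of 2 days; on this read-out higher numbers stand for weaker inhibition and lower numbers for stronger inhibition. The value for compound 1 is a limit of the assay, not a number. The value for compound 2 is likewise a limit. Among the compounds with values here, the only measured step, a step that the two limits leave unreadable from compound 1 to compound 2, therefore cannot be read, as both values sit at the limit of > 30000 nM in this assay, at which 2 of the 2 values shown sit. Compound 3 `Cc1cc(NC(=O)Cn2cc(-c3cccs3)nn2)no1` is not yet measured; it differs from compound 1 by thiophen-2-yl in place of 3-chlorophenyl on an aromatic carbon. Within the data shown here, no measured step touches this position, so no measured evidence bears on its size or direction; the step is expected to be one that stays within the scatter, a number no higher from compound 1 to compound 3 (the limit leaves the size open). Compound 3 is expected to give about 30000 nM in this assay, estimated between 10000 nM and 100000 nM, most likely again as a limit.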

Compound 3, half-maximal inhibitory concentration: > 30000 nM
Compound 3 ended at the assay's limit (the forecaster's own chance of this, stated with the estimate: 75%); the middle value sits exactly at the limit.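

In this assay compound 3 stays at a limit of the assay, as compound 1 does, so the step between them cannot be read: the limit of > 30000 nM in this assay, at which 3 of the 3 values shown sit. The compounds shown leave open how thiophen-2-yl and 3-chlorophenyl compare, and whether any compound on this core gives a readable inhibition value.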